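Aryl groups in place of the alkyne on the shared core

This account rests on a few compounds, and the source may have more. Where it says the series, first, only, none or still open, it means among the compounds named here.

Measured so far:
compound 1 `CCCCC#Cc1cc([C@@H]2O[C@H](CO)[C@@H](O)[C@H]2O)n2ncnc(N)c12` — 1000 nM
compound 2 `Nc1ncnn2c([C@@H]3O[C@H](CO)[C@@H](O)[C@H]3O)cc(-c3ccccc3)c12` — 75100 nM
compound 3 `Nc1ncnn2c([C@@H]3O[C@H](CO)[C@@H](O)[C@H]3O)cc(-c3ccccc3F)c12` — a limit, > 100000 nM

In a functional assay on LN-229 cells (Homo sapiens) for antiproliferative activity, with a stated time of 72 h (a higher number here means a weaker inhibitor, a lower number a stronger inhibitor), compound 1 gives 1000 nM and compound 2 gives 75100 nM. For compound 3 this assay reports only a limit, > 100000 nM, which is the limit of > 100000 nM in this assay, at which 1 of the 3 values shown sits; compound 3 therefore stands at the weak end of the numbers shown. Compound 4 `Nc1ncnn2c([C@@H]3O[C@H](CO)[C@@H](O)[C@H]3O)cc(-c3ccsc3)c12` differs from compound 3 by thiophen-3-yl in place of 2-fluorophenyl on an aromatic carbon.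

Among the compounds with values here, the steps that bear on this change are a 75-fold higher number from compound 1 to compound 2 (1.88 log units; beyond the scatter) and an at least 100-fold higher number from compound 1 to compound 3 (2.00 log units; beyond the scatter), both large, while an at least 1.3-fold higher number from compound 2 to compound 3 (0.12 log units; that floor lies within the scatter). Thiophen-3-yl is again an aromatic ring in the same place as phenyl and 2-fluorophenyl, so compound 4 is expected to remain in the weak range, with an at least 1.4-fold lower number from compound 3 to compound 4 (0.15 log units; that floor lies within the scatter). Compound 4 is estimated at 70000 nM, between 15000 nM and 200000 nM.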

Compound 4, half-maximal inhibitory concentration: 57700 nM
Estimate against measurement, compound 4: 1.2-fold (0.08 log units) above, within the range that was stated.
By their numbers in this assay, from the lowest: compound 1; then compounds 4 and 2 (each within the scatter of the next). At a limit, above all of these: compound 3.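

With thiophen-3-yl in place of phenyl, this assay shows a 1.3-fold lower number from compound 2 to compound 4 (0.11 log units; within the scatter), so a five-membered aromatic ring with a sulfur atom sits level with phenyl at this position. The gap to the alkyne is therefore not confined to six-membered carbon rings: a 58-fold higher number from compound 1 to compound 4 (1.76 log units; beyond the scatter). Compound 3 remains known only as a limit, giving an at least 1.7-fold lower number from compound 3 to compound 4 (0.23 log units; that floor lies within the scatter), so 2-fluorophenyl and thiophen-3-yl cannot be ordered: the limit of > 100000 nM in this assay, at which 1 of the 4 values shown sits.

Still open, going by these compounds, is whether the stronger number of compound 1 rests on the triple bond or on the chain. A saturated hexyl chain or a shorter alkyne on this carbon would separate the two.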